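Cytotoxicity notes on the diaryl ketone series, compound 4

A few compounds are considered here, and "the series" means these few. Any claim that something is new, unique, unknown or untested is made for them only; others in the source may bear on it.

Compound 1, `Cc1ccc(C)c(C(=O)c2c(OCC(=O)Nc3ccc(S(N)(=O)=O)cc3C)ccc3ccccc23)c1`, gives 47500 nM in an ADME assay on C8166 cells (Homo sapiens) for cytotoxicity, read by colorimetric assay and MTT assay; on this read-out lower numbers stand for higher toxicity in this test and higher numbers for lower toxicity in this test.
Compound 2, `Cc1ccc(C(=O)c2c(OCC(=O)Nc3ccc(S(N)(=O)=O)cc3C)ccc3ccccc23)c(C)c1`, gives 25500 nM in this assay.
Compound 3, `Cc1ccc(C(=O)c2c(OCC(=O)Nc3ccc(S(N)(=O)=O)cc3C)ccc3ccccc23)cc1C`, gives 33000 nM in this assay.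

Compound 3 stands second highest of the three numbers. Its nearest neighbour is compound 2, with a 1.3-fold higher number from compound 2 to compound 3 (0.11 log units; within the scatter); its furthest is compound 1, with a 1.4-fold lower number from compound 1 to compound 3 (0.16 log units; within the scatter). The remaining pair shows a 1.9-fold lower number from compound 1 to compound 2 (0.27 log units; within the scatter). All three steps only move methyl groups around the phenyl on the carbonyl carbon, and none of them leaves the scatter, so the three measured compounds are indistinguishable in this assay.

Compound 4, `Cc1cc(S(N)(=O)=O)ccc1NC(=O)COc1ccc2ccccc2c1C(=O)c1cc(Cl)cc(C#N)c1`, differs from compound 3 by 3-chloro-5-cyanophenyl in place of 3,4-dimethylphenyl on a carbonyl carbon. Among the compounds with values here, no measured step exchanges a dimethylphenyl for a halogen- and nitrile-bearing phenyl, so the measured steps bear on this change only in showing that the phenyl on the carbonyl carbon has tolerated rearrangement without a shift beyond scatter. Compound 4 is therefore expected to show no change at the digits printed from compound 3 to compound 4 (within the scatter), that is, no step beyond the scatter, with a wider uncertainty than between the measured pairs. The estimate for compound 4 in this assay is 33000 nM, expected to lie between 12000 nM and 90000 nM.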

Compound 4, half-maximal cytotoxic concentration: 49400 nM
Compound 4: middle estimate off by 1.5-fold (0.18 log units), on the low side; measured number inside the range.
By their numbers in this assay, from the lowest: compounds 2, 3, 1 and 4 (each within the scatter of the next).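

In this assay, within the data shown here, the phenyl on the carbonyl carbon now tolerates a different kind of substitution and not only a rearrangement of methyl groups: 3-chloro-5-cyanophenyl in place of 3,4-dimethylphenyl gives a 1.5-fold higher number from compound 3 to compound 4 (0.18 log units; within the scatter) while the same group in place of 2,4-dimethylphenyl gives a 1.9-fold higher number from compound 2 to compound 4 (0.29 log units; within the scatter) and in place of 2,5-dimethylphenyl gives a 1.0-fold higher number from compound 1 to compound 4 (0.02 log units; within the scatter) so that no step reaches beyond the scatter. The four compounds therefore cannot be told apart at this position, even though the entering group gives up both methyl groups and brings a chlorine, a nitrile and one hydrogen-bond acceptor. Nothing available ties this tolerance to any property of the groups involved.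

Going by these compounds, all four compounds keep a substituted phenyl on the carbonyl carbon, so it stays open whether the number holds with a cyclohexyl group there, or with an amine or a carboxylic acid carried on the phenyl. In this assay the contribution of the shared core also stays unread, since only this one position varies among the compounds shown.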